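Swapping dimethylamino for a methylpyrazole on the shared core

This account rests on a few compounds, and the source may have more. Where it says the series, first, only, none or still open, it means among the compounds named here.

compound 1 `Cc1cc(NNC(=O)Nc2cc(Cl)nc(Cl)c2)ncc1N(C)C` — 5.3 nM
compound 2 `Cc1cc(CO)nc(NNC(=O)Nc2cc(Cl)nc(Cl)c2)c1` — 31 nM
compound 3 `CCOC(=O)c1cc(C)cc(NNC(=O)Nc2cc(Cl)nc(Cl)c2)n1` — 2.1 nM

Three compounds on a shared core were run in a functional assay on CHO cells for antagonist activity at sphingosine 1-phosphate receptor 2 (Homo sapiens), read by scintillation counting and GTPgammaS binding, with a stated time of 4 h, in the presence of a further agent that is not named here; a lower number here means a stronger inhibitor, a higher number a weaker inhibitor. Compound 1 gives 5.3 nM, the second highest number of the three; compound 3 gives the lower 2.1 nM, while compound 2 gives the higher 31 nM. Among the measured compounds shown here, the only single-place step in this set, a 15-fold lower number from compound 2 to compound 3 (1.17 log units; beyond the scatter), concerns another group at another place and speaks only indirectly to the change in question. Compound 4 `Cc1cc(NNC(=O)Nc2cc(Cl)nc(Cl)c2)ncc1-c1ccn(C)n1` differs from compound 1 by 1-methyl-1H-pyrazol-3-yl in place of dimethylamino on an aromatic carbon. For the measured compounds named here, no measured step covers this exchange, so the expected step of a 1.1-fold higher number from compound 1 to compound 4 (0.05 log units; within the scatter) is none beyond the scatter. Compound 4 is accordingly estimated at 6 nM, within a range from 1.5 nM to 25 nM.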

Compound 4, half-maximal inhibitory concentration: 9.3 nM
Beside the measured number, compound 4's estimate is 1.6-fold (0.19 log units) below it; measured number inside the range.
By their numbers in this assay, from the lowest: compound 3; then compounds 1 and 4 (each within the scatter of the next); then compound 2.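

In this assay, this place on the shared core, ortho to a methyl group, accepts a five-membered aromatic ring as readily as an open dimethylamino group: 1-methyl-1H-pyrazol-3-yl in place of dimethylamino gives a 1.8-fold higher number from compound 1 to compound 4 (0.24 log units; within the scatter). Among the compounds shown here, the earlier compounds held no exchange at this place, so this is the first direct reading of it. Nothing measured here explains why the two groups read alike. The compounds shown leave open how a carboxylic acid, a morpholine or a longer chain would fare at this place. They also leave open whether the methyl on the pyrazole matters.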